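A few compounds are considered here, and "the series" means these few. Any claim that something is new, unique, unknown or untested is made for them only; others in the source may bear on it.

Values measured in an ADME assay for pharmacokinetics (on this read-out higher numbers stand for a longer-lived compound and lower numbers for a shorter-lived compound), are these:

- compound 1 (`CC[C@H]1C(=O)N2C(C(=O)OCc3ccc(C(=O)O)cc3)=C(COC(C)=O)CS(=O)(=O)[C@H]12`): 40 h
- compound 2 (`COC(=O)c1ccc(COC(=O)C2=C(COC(C)=O)CS(=O)(=O)[C@@H]3[C@@H](OC)C(=O)N23)cc1`): < 5 h (a limit of the assay, not a number)
- compound 3 (`CO[C@H]1C(=O)N2C(C(=O)N(C)CC(=O)O)=C(CSc3nc(=O)c(=O)[nH]n3C)CS(=O)(=O)[C@H]12`): 22 h

Compound 3 (22 h) sits within the usual scatter of compound 1 (40 h). Compound 2 is reported only as a limit (< 5 h).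

Compound 4 (`CO[C@H]1C(=O)N2C(C(=O)N3CCCC3C(=O)O)=C(CSc3nc(=O)c(=O)[nH]n3C)CS(=O)(=O)[C@H]12`) differs from compound 3 in one place (2-carboxypyrrolidin-1-yl in place of (carboxymethyl)(methyl)amino on a carbonyl carbon): 2-carboxypyrrolidin-1-yl stands in place of (carboxymethyl)(methyl)amino on a carbonyl carbon. Among the compounds with values here, no measured pair of compounds shows this change, so the data offer no direct guide to its size. In this assay no step beyond the scatter is expected (a 1.1-fold lower number from compound 3 to compound 4 (0.04 log units; within the scatter)). For compound 4 the estimated half-life is 20 h with an expected range (10 h to 40 h).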

Compound 4, half-life: 46 h
Beside the measured number, compound 4's estimate is 2.3-fold (0.36 log units) below it; measured number outside the range, above it.
By their numbers in this assay, from the lowest: compounds 3, 1 and 4 (each within the scatter of the next, the first and the last beyond it). At a limit, below all of these: compound 2.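

The group on this carbonyl carbon can change the half-life: in this assay, replacing the open (carboxymethyl)(methyl)amino group with the ring of 2-carboxypyrrolidin-1-yl gives a 2.1-fold higher number from compound 3 to compound 4 (0.32 log units; beyond the scatter) and this modest step lies beyond the scatter. Within the data shown here, the earlier compounds offered no pair differing in one place, so this is the first direct reading of any change here. Nothing measured here accounts for the step. From the compounds shown here alone, whether the ring itself matters, or only the larger group, stays open. A six-membered 2-carboxypiperidin-1-yl at this place would help separate the two.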